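The source may report more compounds than this note shows. Statements on the series, on what has been measured and on what is new or still open speak of the compounds shown alone.

Measured so far:
Compound 1, `COc1cc(-c2cc(/C=C/C(=O)c3ccc(N)cc3)[nH]n2)cc(OC)c1OC`, in a functional assay on NCI-H322M cells (Homo sapiens) for inhibition, read by sulforhodamine B assay, with a stated time of 48 h (a higher number here means that more compound is tolerated, a lower number that less compound is tolerated), compound 1 gives 20900 nM.
Compound 2, `COc1ccc(C(=O)/C=C/c2cc(-c3cc(OC)c(OC)c(OC)c3)n[nH]2)cc1OC`, in this assay compound 2 gives 5510 nM.
Compound 3, `COc1ccc(-c2cc(/C=C/C(=O)c3ccc(N)cc3)[nH]n2)cc1OC`, in this assay compound 3 gives 46200 nM.

Of these three, compound 2 gives the lowest number. Compound 4, `COc1cc(C(=O)/C=C/c2cc(-c3cc(OC)c(OC)c(OC)c3)n[nH]2)cc(OC)c1OC`, has not been measured. It differs from compound 2 in one place: methoxy in place of hydrogen on an aromatic carbon. The same change was made once before, from compound 3 to compound 1: methoxy in place of hydrogen on an aromatic carbon. That step gave a 2.2-fold lower number from compound 3 to compound 1 (0.34 log units; beyond the scatter). The cores of compound 2 and compound 3 are not the same, and the difference between the two cores is not broken down here. As the two place descriptions read alike, the change to compound 4 is treated as the same change. A step of a 2.1-fold lower number from compound 2 to compound 4 (0.33 log units; beyond the scatter) is expected because a 2.2-fold lower number from compound 3 to compound 1 (0.34 log units; beyond the scatter) went the same way on the other core. Compound 4 is thus estimated at 2600 nM, with a likely range from 1100 nM to 6000 nM.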

Compound 4, concentration lethal to 50% of the cells: 14400 nM
For compound 4 the middle estimate is 5.5-fold (0.74 log units) below the measured one; the measured number lies above the stated range.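

In this assay, methoxy in place of hydrogen on an aromatic carbon gave a 2.6-fold higher number from compound 2 to compound 4 (0.42 log units; beyond the scatter), so the change did not keep its direction from one core to the other. Set side by side, the two steps disagree: the same change on two cores in this assay, a 2.2-fold lower number (0.34 log units; beyond the scatter) from compound 3 to compound 1 and a 2.6-fold higher number (0.42 log units; beyond the scatter) from compound 2 to compound 4, 5.8-fold (0.76 log units) apart, beyond the scatter of two such steps. This shows that, in this series, the step on one core is no reliable guide to the step on the other, but two pairs do not show which difference between the cores goes with the reversal.

The compounds shown leave open whether the reversal is particular to methoxy. A hydroxy group or an ethoxy group in the same place on each core might show whether it also appears with other groups.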